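Branching the carbamate chain of a selenocyanate

The compounds below may be only part of what the source reports. "The series", "measured", "known", "first", "only" and "open" are said of these compounds alone.

Measured so far:
compound 1 `CCCOC(=O)Nc1ccc([Se]C#N)cc1` — 21100 nM
compound 2 `CCOC(=O)Nc1ccc([Se][Se]c2ccc(NC(=O)OCC)cc2)cc1` — 28800 nM

In a functional assay on PC-3 cells (Homo sapiens) for cytotoxicity, read by MTT assay, with a stated time of 72 h (a lower number here means a stronger inhibitor of growth, a higher number a weaker inhibitor of growth), compound 1 gives 21100 nM, and compound 2, in which two of the carbamate-bearing rings are joined through a pair of selenium atoms, gives 28800 nM in the same assay. Of the two numbers, that of compound 1 is the smaller, but the gap between them lies within the usual scatter, so no real difference between the two can be claimed.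

Compound 3 `CC(C)COC(=O)Nc1ccc([Se]C#N)cc1` has not yet been measured. It differs from compound 1 by methyl in place of hydrogen on a saturated chain carbon bound to two saturated chain carbons: the propyl group of the carbamate becomes an isobutyl group, while the selenocyanate and the rest of the core stay the same. Within the data shown here, no measured pair in this set shows what such a change does. A single added methyl on the chain would be expected to leave the number where it is, with no step beyond the scatter.

Compound 3 is therefore estimated at 20000 nM, within 8000 nM to 50000 nM, a step of a 1.1-fold lower number from compound 1 to compound 3 (0.02 log units; within the scatter).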

Compound 3, concentration for 50% growth inhibition: 21600 nM
Estimate against measurement, compound 3: 1.1-fold (0.03 log units) below, and the stated range covers the measured number.
By their numbers in this assay, from the lowest: compounds 1, 3 and 2 (each within the scatter of the next).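

In this assay, methyl in place of hydrogen on a saturated chain carbon bound to two saturated chain carbons, which turns the propyl group into an isobutyl group, gives a 1.0-fold higher number from compound 1 to compound 3 (0.01 log units; within the scatter) and so no difference that can be claimed. Among these compounds, compound 1 and compound 3 are the only pair here that differ in one place, so they give the only direct reading of a change in the carbamate chain: at this position, one added methyl and the branch it creates leave growth inhibition in these cells indistinguishable from that of the unbranched chain. No separate measurement bears on this result, so the reason for it remains unknown.

This single branch says little about the chain as a whole, and a longer chain such as hexyl, a phenyl ring or an amine at the chain end could still give a different number. From the compounds shown here alone, compound 2 differs from compound 1 and compound 3 in more than one place, so its value cannot be tied to any single change, and the part played by the selenocyanate stays open.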